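The compounds below may be only part of what the source reports. "The series", "measured", "known", "first", "only" and "open" are said of these compounds alone.

Working notes on the series.

For the measured compounds named here, compound 3 `Cc1ccc(C(=O)N2N=C(c3cc4ccccc4oc3=O)CC2c2ccccc2)cc1` stands second highest of the three numbers so far in a functional assay on PC-3 cells (Homo sapiens) for cytotoxicity, read by MTT assay, with a stated time of 48 h (on this read-out lower numbers stand for stronger inhibition and higher numbers for weaker inhibition), where compound 3 gives 13200 nM. Its nearest neighbour on the scale is compound 1 `COc1ccccc1C1CC(C)=NN1C(=O)CN1CCC(OC)CC1`, which in this assay gives 27200 nM; furthest away is compound 2 `CC[N+](C)(CC)CC(=O)N1N=C(C)CC1c1ccccc1OC`, which gives 4170 nM.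

Compound 4 `CNCC(=O)N1N=C(c2cc3ccccc3oc2=O)CC1c1ccccc1` is not yet measured. It differs from compound 3 by (methylamino)methyl in place of 4-methylphenyl on a carbonyl carbon, which reads, cut one bond further out, as (4-methylphenyl)carbonyl to ((methylamino)methyl)carbonyl.

Going by the values given here, the only measured step that touches the carbonyl side chain is a 6.5-fold lower number from compound 1 to compound 2 (0.81 log units; beyond the scatter), where one amine-bearing group replaced another on a saturated chain carbon bound to a carbonyl carbon. Among the compounds with values here, no measured step swaps an aryl group for an aminomethyl group, so that step bears on the present change only loosely. A modest shift in this assay, either direction, is the most that can be read from it.

Compound 4 is therefore expected to give about 10000 nM in this assay, within 3000 nM to 35000 nM, an estimated step of a 1.3-fold lower number from compound 3 to compound 4 (0.12 log units; within the scatter).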

Compound 4, half-maximal inhibitory concentration: 2300 nM
For compound 4 the middle estimate is 4.3-fold (0.64 log units) above the measured one, and the stated range ends above it.
By their numbers in this assay, from the lowest: compounds 4 and 2 (each within the scatter of the next); then compound 3; then compound 1.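

On a carbonyl carbon whose other neighbours are an amide-type nitrogen in a ring, (methylamino)methyl in place of 4-methylphenyl gives in this assay a 5.7-fold lower number from compound 3 to compound 4 (0.76 log units; beyond the scatter), a shift beyond the scatter. Within this pair, the 4-methylphenyl ring is therefore not required for the read-out, and an open chain carrying an amine in its place gives the lower number. No available evidence accounts for the size or direction of this step.

The two compounds do not separate the loss of the 4-methylphenyl ring from the arrival of the amine, a question that a plain methyl or an unsubstituted phenyl on the same carbonyl would address. Also open, as far as these compounds go, is how a dimethylamino group, a longer chain ending in an amine, or a carboxylic acid would read on the core of compound 4.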